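Methylsulfonyl for methyl: compound 4 on a urea series

The source may hold more compounds than are shown below. What is called first, only, known or untested is meant among the compounds shown, and "the series" means these compounds.

Compound 1, `Cc1ccc(NC(=O)Nc2cccc(CNc3nccnc3Cl)c2)cc1`, gives 11500 nM in a functional assay on HepG2 cells (Homo sapiens) for antiproliferative activity, read by MTT assay, with a stated time of 48 h; a higher number here means a weaker inhibitor, a lower number a stronger inhibitor.
Compound 2, `O=C(Nc1cccc(CNc2nccnc2Cl)c1)Nc1ccc(Cl)cc1Cl`, gives 7230 nM in this assay.
Compound 3, `CCc1ccccc1NC(=O)Nc1cccc(CNc2nccnc2Cl)c1`, gives 7860 nM in this assay.

Among these three, compound 1 has the highest number, yet its steps to the others, a 1.6-fold lower number from compound 1 to compound 2 (0.20 log units; within the scatter) and a 1.5-fold lower number from compound 1 to compound 3 (0.17 log units; within the scatter), both lie within the scatter, so the three stand together. Compound 4, `CS(=O)(=O)c1ccc(NC(=O)Nc2cccc(CNc3nccnc3Cl)c2)cc1`, differs from compound 1 as follows: methylsulfonyl in place of methyl on an aromatic carbon. Going by the values given here, neither measured step changes the para substituent of a 4-methylphenyl group, so no step bears directly on this change; all measured steps are small. Compound 4 is therefore expected to show no step beyond the scatter, a 1.2-fold lower number from compound 1 to compound 4 (0.06 log units; within the scatter). The estimate for compound 4 in this assay is 10000 nM, ranging from 3500 nM to 28000 nM.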

Compound 4, half-maximal inhibitory concentration: 15100 nM
The estimate for compound 4 lay 1.5-fold (0.18 log units) below the measured number; measured number inside the range.
By their numbers in this assay, from the lowest: compounds 2, 3, 1 and 4 (each within the scatter of the next, the first and the last beyond it).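

Methylsulfonyl in place of methyl on an aromatic carbon, para to a large group, gives a 1.3-fold higher number from compound 1 to compound 4 (0.12 log units; within the scatter) in this assay. The earlier steps shown here exchanged the whole group on the amide-type nitrogen, whereas this one alters a single substituent, and even a group of four heavy atoms carrying two hydrogen-bond acceptors leaves the number within the scatter of the methyl compound. Nothing available explains this result.

On these data alone, what an amine or a carboxylic acid at this place would give remains open, as does whether any substituent here can move the number beyond the scatter.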